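The compounds below may be only part of what the source reports. "The series", "measured", "known", "first", "only" and "open" are said of these compounds alone.

Compound 2 `O=C(NCc1ccncc1)Nc1ccc(S(=O)(=O)c2ccccc2Cl)cc1` carries a urea linking a pyridinylmethyl group to a benzene ring that bears a sulfonyl group. In an assay on isolated protein for activation of Nicotinamide phosphoribosyltransferase (Homo sapiens) (a higher number here means that more compound is needed for the effect, a lower number that less compound is needed), compound 2 gives 79 nM, the lowest number of the three measured compounds. Compound 3 `CCOC(=O)c1ccc(NC(=O)NCc2c[nH]nn2)cc1` gives 7750 nM, and compound 1 `CCOC(=O)c1ccc(NC(=O)NCc2cocn2)cc1` gives 27600 nM; both sit well above compound 2, beyond the scatter.

Compound 4 `CNS(=O)(=O)c1ccc(NC(=O)NCc2ccncc2)cc1` differs from compound 2 in one place: methylamino in place of 2-chlorophenyl on a sulfonyl sulfur. Within the data shown here, the only measured step, a 3.6-fold lower number from compound 1 to compound 3 (0.55 log units; beyond the scatter), changes the five-membered ring at the other end of the urea and therefore says nothing about what sits on the sulfonyl sulfur. Among the measured compounds shown here, compounds 1 and 3 differ from compound 2 in two places at once, so their values show only that compounds with an ethyl ester in place of the whole sulfonyl group are far less potent, not how much of that rests on the 2-chlorophenyl group.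

For the measured compounds named here, with no direct precedent, the expectation for compound 4 is a higher number, as the change removes the one aromatic ring attached to the sulfonyl sulfur, giving an estimated step of a 25-fold higher number from compound 2 to compound 4 (1.40 log units; beyond the scatter). Compound 4 is therefore estimated at 2000 nM, within a range from 400 nM to 10000 nM.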

Compound 4, half-maximal effective concentration: 3230 nM
For compound 4 the middle estimate is 1.6-fold (0.21 log units) below the measured one, within the range that was stated.
By their numbers in this assay, from the lowest: compound 2; then compound 4; then compound 3; then compound 1.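

In this assay, among these compounds, replacing 2-chlorophenyl with methylamino on the sulfonyl sulfur gives a 41-fold higher number from compound 2 to compound 4 (1.61 log units; beyond the scatter), a large step and the first direct reading of this position, since the earlier step changed only the five-membered ring at the other end of the urea. Among the compounds shown here, with the rest of the molecule held constant, the low number of compound 2 clearly depends on what sits at this one place, but the swap changes several things at once: an aromatic ring and a chlorine leave, the group becomes much smaller, and a hydrogen-bond donor enters, so the single step cannot say which of these matters. No measurement of any property of these two groups is available to account for the size of the step.

A plain phenyl group on the sulfonyl sulfur would separate the part played by the chlorine from that of the ring, while a cyclohexyl group would test whether the ring needs to be aromatic. As far as these compounds go, a methyl group on the sulfur, or a dimethylamino group, would likewise show whether the hydrogen on the methylamino nitrogen matters, and these questions remain open.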